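A few compounds are considered here, and "the series" means these few. Any claim that something is new, unique, unknown or untested is made for them only; others in the source may bear on it.

Three related compounds have been tested so far in a functional assay on SMMC-7721 cells (Homo sapiens) for cytotoxicity, read by MTT assay, with a stated time of 24 h (on this read-out lower numbers stand for stronger inhibition and higher numbers for weaker inhibition), and their numbers lie close together. Compound 1 (`N#Cc1ccc(S(=O)(=O)N2C/C(=C\c3cccnc3)C(=O)/C(=C/c3ccccc3F)C2)cc1`) gives 15400 nM in this test, compound 2 (`O=C1/C(=C/c2ccncc2)CNC/C1=C\c1ccccc1F`) gives 18400 nM and compound 3 (`O=C1/C(=C/c2ccncc2)CN(S(=O)(=O)c2ccc(C(F)(F)F)cc2)C/C1=C\c1ccccc1F`) gives 11100 nM on the same scale. The number for compound 3 lies within the usual scatter of the numbers for both compound 1 and compound 2, so it cannot be told apart from either of them.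

Compound 4 (`N#Cc1ccc(S(=O)(=O)N2C/C(=C\c3ccncc3)C(=O)/C(=C/c3ccccc3F)C2)cc1`) departs from compound 3 at a single place (cyano in place of trifluoromethyl on an aromatic carbon) with cyano in place of trifluoromethyl on an aromatic carbon, para to a large group. For the measured compounds named here, no measured pair isolates this exchange, so the data offer no direct guide to it. The nearest evidence is a molecule that carries the same 4-cyanophenyl group but differs from compound 4 elsewhere, namely compound 1 at 15400 nM. That number stays within the scatter of the number for compound 3. The expected shift is therefore small, estimated as a 1.2-fold higher number from compound 3 to compound 4 (0.07 log units; within the scatter) in the direction of a slightly higher number and not beyond the scatter. Compound 4 is estimated at 13000 nM with an expected range from 7000 nM to 24000 nM in this measurement.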

Compound 4, half-maximal inhibitory concentration: 16200 nM
Compound 4: the middle estimate sits 1.2-fold (0.10 log units) below what was measured; the range from low to high includes it.
By their numbers in this assay, from the lowest: compounds 3, 1, 4 and 2 (each within the scatter of the next).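

In this assay, for the compounds shown here, the exchange of trifluoromethyl for cyano on the aromatic carbon, para to a large group, gives a 1.5-fold higher number from compound 3 to compound 4 (0.16 log units; within the scatter) and is the first direct reading of this change, which leaves the number within the scatter. The two other single-place comparisons read the same way: placing (4-cyanophenyl)sulfonyl on the ring amine nitrogen in place of hydrogen gives a 1.1-fold lower number from compound 2 to compound 4 (0.06 log units; within the scatter) and the exchange of pyridin-3-yl for pyridin-4-yl gives a 1.1-fold higher number from compound 1 to compound 4 (0.02 log units; within the scatter), so neither the sulfonyl group on that nitrogen nor this change in the pyridine separates the compounds in this test. No supporting measurement is available to explain these results.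

As far as these compounds go, whether a different group on the same aromatic carbon, such as an amine or a carboxylic acid, would produce a step beyond the scatter remains open. With every step so far inside the scatter, the compounds shown also leave open which part of the structure, if any, governs the number in this assay.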